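A few compounds are considered here, and "the series" means these few. Any claim that something is new, unique, unknown or untested is made for them only; others in the source may bear on it.

Values in a functional assay on A549 cells (Homo sapiens) for antiproliferative activity, read by MTT assay, with a stated time of 24 h; a higher number here means a weaker inhibitor, a lower number a stronger inhibitor:
- compound 1 `O=C(NNc1ccccc1Cl)c1ccc(NS(=O)(=O)c2cnc(O)nc2O)cc1`: 3340 nM
- compound 2 `O=C(NNc1ccc(F)cc1)c1ccc(NS(=O)(=O)c2cnc(O)nc2O)cc1`: > 20000 nM (a limit, not a number)
- compound 3 `CCCCOc1ccc(C(=O)NNC(=O)c2ccc(NS(=O)(=O)c3cnc(O)nc3O)cc2)cc1`: 9010 nM

Not yet measured: compound 4 `Cc1ccc(C(=O)NNC(=O)c2ccc(NS(=O)(=O)c3cnc(O)nc3O)cc2)cc1`.

Of the two numeric values, the higher belongs to compound 3 at 9010 nM, and the gap to compound 1 at 3340 nM lies beyond the scatter.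

The change under review is methyl in place of butoxy on an aromatic carbon, para to a large group: methyl in place of butoxy on an aromatic carbon.

For the measured compounds named here, no measured step covers this change. The nearest guide is an at least 5.9-fold higher number from compound 1 to compound 2 (0.77 log units; beyond the scatter), with 4-fluorophenyl in place of 2-chlorophenyl on an amine nitrogen. That step ends at a limit, (the limit of > 20000 nM in this assay, at which 1 of the 3 values shown sits), so it gives only a lower bound on its size. It shows that a swap on an outer aromatic ring can move the number in this series, but it sets no direction for the loss of butoxy.

With no direction to go on, the expected step is a 1.0-fold lower number from compound 3 to compound 4 (0.00 log units; within the scatter), with none beyond the scatter as the central expectation, though the uncertainty is wide.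

The estimate for compound 4 is 9000 nM, with an expected range from 3000 nM to 25000 nM.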

Compound 4, half-maximal inhibitory concentration: 15900 nM
Beside the measured number, compound 4's estimate is 1.8-fold (0.25 log units) below it; measured number inside the range.
By their numbers in this assay, from the lowest: compound 1; then compounds 3 and 4 (each within the scatter of the next). At a limit, above all of these: compound 2.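

In this assay methyl in place of butoxy on an aromatic carbon, para to a large group, gives a 1.8-fold higher number from compound 3 to compound 4 (0.25 log units; within the scatter), so butoxy and methyl cannot be told apart at this position. The 4-methylphenyl compound still separates from the 2-chlorophenyl compound, with (4-methylphenyl)carbonyl in place of 4-chlorophenyl on an amine nitrogen (a 4.8-fold higher number from compound 1 to compound 4 (0.68 log units; beyond the scatter)). With (4-methylphenyl)carbonyl in place of 4-fluorophenyl on an amine nitrogen the step is an at least 1.2-fold lower number from compound 2 to compound 4 (0.09 log units; that floor lies within the scatter), and it gives only a floor, since compound 2 stands at a limit, not a number: the limit of > 20000 nM in this assay, at which 1 of the 4 values shown sits.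

From the compounds shown here alone, whether any group at this position separates from butoxy and methyl remains open, for example an amine, a carboxylic acid or a chain longer than butoxy. The shown compounds also leave open whether plain hydrogen there would sit with these two values.

Correction: the second sentence above should read "in place of 2-chlorophenyl", as in the original part. The corrected whole part is:

In this assay methyl in place of butoxy on an aromatic carbon, para to a large group, gives a 1.8-fold higher number from compound 3 to compound 4 (0.25 log units; within the scatter), so butoxy and methyl cannot be told apart at this position. The 4-methylphenyl compound still separates from the 2-chlorophenyl compound, with (4-methylphenyl)carbonyl in place of 2-chlorophenyl on an amine nitrogen (a 4.8-fold higher number from compound 1 to compound 4 (0.68 log units; beyond the scatter)). With (4-methylphenyl)carbonyl in place of 4-fluorophenyl on an amine nitrogen the step is an at least 1.2-fold lower number from compound 2 to compound 4 (0.09 log units; that floor lies within the scatter), and it gives only a floor, since compound 2 stands at a limit, not a number: the limit of > 20000 nM in this assay, at which 1 of the 4 values shown sits.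

Going by these compounds, whether any group at this position separates from butoxy and methyl remains open, for example an amine, a carboxylic acid or a chain longer than butoxy. The shown compounds also leave open whether plain hydrogen there would sit with these two values.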